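Methyl on the Amine in a Series Without Measurable Potency

This account rests on a few compounds, and the source may have more. Where it says the series, first, only, none or still open, it means among the compounds named here.

Measured compounds:
compound 1 `CNc1ncnc2c1c(-c1ccsc1)cn2[C@@H]1O[C@H](CO)[C@@H](O)[C@H]1O`; in a functional assay on CEM-DNR-bulk cells (Homo sapiens), read by MTT assay, with a stated time of 72 h (a higher number here means a weaker inhibitor, a lower number a stronger inhibitor), compound 1 reaches only a limit, > 20000 nM.
compound 2 `CNc1ncnc2c1c(-c1cccs1)cn2[C@@H]1O[C@H](CO)[C@@H](O)[C@H]1O`; in this assay compound 2 likewise reaches only a limit, > 20000 nM.
compound 3 `CNc1ncnc2c1c(-c1ccoc1)cn2[C@@H]1O[C@H](CO)[C@@H](O)[C@H]1O`; in this assay compound 3 again reaches only a limit, > 20000 nM.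

Compound 1 therefore stands at the edge of what this assay reports, and no ranking among the three is possible, because of the limit of > 20000 nM in this assay, at which 3 of the 3 values shown sit. The steps a step that the two limits leave unreadable from compound 1 to compound 2, a step that the two limits leave unreadable from compound 1 to compound 3 and a step that the two limits leave unreadable from compound 2 to compound 3 are all unreadable for the same reason.

Compound 4 `CN(C)c1ncnc2c1c(-c1ccsc1)cn2[C@@H]1O[C@H](CO)[C@@H](O)[C@H]1O` differs from compound 1 by methyl in place of hydrogen on a nitrogen on an aromatic ring. Among the measured compounds shown here, no measured step touches this nitrogen; the measured steps all change the aromatic substituent and all end at the limit. They give no direction for this change in this assay, and the expectation can only be that compound 4 stays near the limit as well. The estimated step that the limit leaves unreadable from compound 1 to compound 4 is expected to be no more than scatter. Compound 4 is therefore estimated at 30000 nM, within 10000 nM to 100000 nM, most likely reported as a limit.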

Compound 4, half-maximal inhibitory concentration: > 20000 nM
Compound 4: only a limit was reported; the forecaster's own chance of this, stated with the estimate: 85%; the middle value does not contradict the limit.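

In this assay compound 4 gives > 20000 nM as a limit only. Among the compounds shown here, no step from compound 1 to compound 4 can be read, because both compounds end at the same edge: the limit of > 20000 nM in this assay, at which 4 of the 4 values shown sit. The compounds shown leave open what the methylamino to dimethylamino change does wherever a measurable value exists.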